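From compound 2 to compound 4: tert-butyl on the carbonyl

The source may report more compounds than this note shows. Statements on the series, on what has been measured and on what is new or still open speak of the compounds shown alone.

Values in a functional assay on RPMI-8226 cells (Homo sapiens) for cytotoxicity, read by MTT assay, with a stated time of 48 h; on this read-out higher numbers stand for weaker inhibition and lower numbers for stronger inhibition
compound 1 `C#CCOC(=O)NN=C1C(Cl)=C(Cl)C(Cl)=C1Cl` gives 800 nM
compound 2 `C#CC(C)(C)OC(=O)NN=C1C(Cl)=C(Cl)C(Cl)=C1Cl` gives > 5000 nM ( a limit )
compound 3 `ClC1=C(Cl)C(Cl)=C(Cl)C1=NNC1CCCCC1` gives > 3000 nM ( a limit )
compound 4 `CC(C)(C)C(=O)NN=C1C(Cl)=C(Cl)C(Cl)=C1Cl` is not yet measured

Compound 2 reads > 5000 nM in this assay and this entry is a limit, not a number. Compound 3 reads > 3000 nM in the same test and this entry is also a limit. Of the three, only compound 1 has a true number, 800 nM in this assay as its reading.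

The change to compound 4 is tert-butyl in place of (1,1-dimethylprop-2-yn-1-yl)oxy on a carbonyl carbon and so the triple bond goes with the departing group. Among the compounds with values here, one measured step bears on it: an at least 6.2-fold higher number from compound 1 to compound 2 (0.79 log units; beyond the scatter) is beyond the scatter and alters the same group that compound 4 gives up. That step ends in a limit, so it sets no firm size for a further change. Compound 4 does not regain the propargyl group of compound 1 800 nM and so no recovery to that level is expected. No step beyond the scatter is expected in this assay in either direction. The expected step is an at least 1.2-fold lower number from compound 2 to compound 4 (0.09 log units; that floor lies within the scatter) and it is estimated to stay within the scatter. For compound 4 the estimated value is 4000 nM with an expected range of 1200 nM to 12000 nM around it.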

Compound 4, half-maximal inhibitory concentration: 90 nM
Beside the measured number, compound 4's estimate is 44-fold (1.65 log units) above it; the measured number lies below the stated range.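

On a carbonyl carbon whose other neighbour is an amide-type nitrogen, tert-butyl in place of (1,1-dimethylprop-2-yn-1-yl)oxy gives an at least 55-fold lower number from compound 2 to compound 4 (1.74 log units; beyond the scatter) in this assay, so a triple bond on this group is not needed for a low number in the series. The comparison with the propargyl compound runs the same way, with an 8.9-fold lower number from compound 1 to compound 4 (0.95 log units; beyond the scatter), and a carbon bearing two methyl groups is present in both compound 2 and compound 4, so that branching alone does not set a weak reading. The entry for compound 2 is a limit and the first step gives only a floor for the size of the change: the limit of > 5000 nM in this assay, at which 1 of the 4 values shown sits.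

The change removes the oxygen and the triple bond together, and the compounds shown do not separate the two. On these data alone, it also remains open whether other groups on the same carbonyl carbon, such as isopropyl, cyclohexyl, phenyl or a longer alkyl chain, keep the reading near that of compound 4 or lose it.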